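Para-chloro on the benzylamide of an EP1 sulfonamide series

This account rests on a few compounds, and the source may have more. Where it says the series, first, only, none or still open, it means among the compounds named here.

Measured so far:
compound 1, `CCc1ccccc1N(CC(=O)NCc1ccc(OC)c(OC)c1)S(=O)(=O)c1ccc(C)cc1`: 25.1 nM
compound 2, `CCc1ccccc1N(CC(=O)NCc1ccccc1)S(=O)(=O)c1ccc(C)cc1`: 63.1 nM

Of the compounds shown here, two have been tested in an assay on CHO cells for displacement of a labelled ligand from prostaglandin E2 receptor EP1 subtype (Homo sapiens); a lower number here means a stronger inhibitor, a higher number a weaker inhibitor. Compound 1, `CCc1ccccc1N(CC(=O)NCc1ccc(OC)c(OC)c1)S(=O)(=O)c1ccc(C)cc1`, gives 25.1 nM. Compound 2, `CCc1ccccc1N(CC(=O)NCc1ccccc1)S(=O)(=O)c1ccc(C)cc1`, gives 63.1 nM and so has the higher of the two numbers; the step of a 2.5-fold higher number from compound 1 to compound 2 (0.40 log units; beyond the scatter) shows how far it lies from compound 1. The next compound, compound 3, `CCc1ccccc1N(CC(=O)NCc1ccc(Cl)cc1)S(=O)(=O)c1ccc(C)cc1`, differs from compound 2 in one place: chloro in place of hydrogen on an aromatic carbon. Going by the values given here, no measured pair shows a chloro entering, so only the step from compound 1 to compound 2 bears on it, and only loosely: substitution on that aromatic ring of carbon only gave a lower number there. Compound 3 is therefore expected to give a somewhat lower number than compound 2, a step of a 1.4-fold lower number from compound 2 to compound 3 (0.15 log units; within the scatter), close to the scatter. The estimate for compound 3 is 45 nM, within 15 nM to 130 nM.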

Compound 3, inhibition constant: 10 nM
Estimate against measurement, compound 3: 4.5-fold (0.65 log units) above; the whole stated range lies above it.
By their numbers in this assay, from the lowest: compound 3; then compound 1; then compound 2.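

In this assay the change from benzyl to 4-chlorobenzyl gives a 6.3-fold lower number from compound 2 to compound 3 (0.80 log units; beyond the scatter), so this one position on the ring can by itself move the number well beyond the scatter. The 4-chlorophenyl group also compares favourably with the 3,4-dimethoxyphenyl group, with a 2.5-fold lower number from compound 1 to compound 3 (0.40 log units; beyond the scatter), which shows that the dimethoxy pattern is not needed for a low number in this series. No measurement at hand bears on why the chloro has this effect.

As far as these compounds go, whether the drop belongs to chlorine in particular or to substitution at this carbon more generally remains open, and a fluoro, methyl or single methoxy at the same place would bear on that. Also open, from the compounds shown here alone, is how a carboxylic acid or an amine would fare there.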